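A few compounds are considered here, and "the series" means these few. Any claim that something is new, unique, unknown or untested is made for them only; others in the source may bear on it.

Compound 3, `CCC(Oc1ccc(-n2cc(C(F)(F)F)cn2)cc1)c1ccc(C(=O)NCCC(=O)O)cc1`, gives 1400 nM in an assay on cells for displacement of a labelled ligand from Glucagon receptor (Homo sapiens), in the presence of a further agent that is not named here (on this read-out higher numbers stand for weaker inhibition and lower numbers for stronger inhibition), the highest of the three numbers recorded there. Compound 2, `CCCC(Oc1ccc(-n2cc(Cl)cn2)cc1)c1ccc(C(=O)NCCC(=O)O)cc1`, gives 1100 nM in this assay, and the gap between compound 3 and compound 2 lies within the scatter of repeated measurements, so the two cannot be told apart. Compound 1, `CCCC(Oc1ccc(-n2cc(C(F)(F)F)cn2)c(C)c1)c1ccc(C(=O)NCCC(=O)O)cc1`, gives 200 nM in this assay, a lower number than that of compound 3, and this gap lies beyond the scatter. Compound 4, `O=C(O)CCNC(=O)c1ccc(C(Oc2ccc(-n3cc(C(F)(F)F)cn3)cc2)C2CCCC2)cc1`, has not yet been measured in this assay. It differs from compound 3 in one place: cyclopentyl in place of ethyl on a saturated chain carbon bound to an aromatic carbon and an oxygen on an aromatic ring. Among the measured compounds shown here, no measured pair shows this exact change, so any expectation rests on the wider picture, in which the group at this saturated chain carbon varies among compounds 1, 2 and 3 alongside other changes. Compound 4 is expected to give a somewhat lower number than compound 3, with a step of a 3.1-fold lower number from compound 3 to compound 4 (0.49 log units; beyond the scatter) estimated. For compound 4 the estimate in this assay is 450 nM, within a range from 150 nM to 1400 nM.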

Compound 4, inhibition constant: 420 nM
The estimate for compound 4 lay 1.1-fold (0.03 log units) above the measured number, within the range that was stated.
By their numbers in this assay, from the lowest: compound 1; then compound 4; then compounds 2 and 3 (each within the scatter of the next).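

In this assay the exchange of ethyl for cyclopentyl on the saturated chain carbon bound to an aromatic carbon and an oxygen on an aromatic ring gives a 3.3-fold lower number from compound 3 to compound 4 (0.52 log units; beyond the scatter), a modest step. Among the compounds shown here, the earlier compounds varied the group at this carbon only alongside other changes, so this pair is the first to read that group alone, and it shows that this position tolerates a ring in place of a short chain without loss of inhibition. No measurement shown here bears on what lies behind the step.

As far as these compounds go, what cyclopropyl, cyclohexyl or phenyl would give at this carbon stays open, so it cannot be said whether ring size matters. Propyl occurs only in compounds that differ elsewhere too, so an open chain cannot be set directly against cyclopentyl.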